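The source may hold more compounds than are shown below. What is called first, only, known or untested is meant among the compounds shown, and "the series" means these compounds.

Measured in a functional assay on NCI-H661 cells (Homo sapiens) for inhibition, read by MTT assay, with a stated time of 72 h; on this read-out lower numbers stand for stronger inhibition of growth and higher numbers for weaker inhibition of growth:

- compound 1 `CN(C)/C=N/c1c(C=O)c(-c2ccccc2)nn1-c1ccccc1`: 31400 nM
- compound 2 `Cc1cccc(-n2nc(-c3ccccc3)c(C=O)c2/N=C/N(C)C)c1`: 31000 nM
- compound 3 `CN(C)/C=N/c1c(C=O)c(-c2ccccc2)nn1-c1cccc([N+](=O)[O-])c1`: 50000 nM

Compound 2 has the lowest number of the three, but its gap to compound 1 is negligible and its gap to compound 3 is also within the scatter, so no order among the three can be claimed. The three measured steps all concern the ring on the aromatic nitrogen of the shared core: a 1.0-fold lower number from compound 1 to compound 2 (0.01 log units; within the scatter), a 1.6-fold higher number from compound 1 to compound 3 (0.20 log units; within the scatter) and a 1.6-fold higher number from compound 2 to compound 3 (0.21 log units; within the scatter). Every one of them is within the scatter.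

Compound 4 `CN(C)/C=N/c1c(C=O)c(-c2ccccc2)nn1-c1ccc(Br)cc1` carries the change (4-bromophenyl in place of 3-methylphenyl on an aromatic nitrogen). Within the data shown here, no measured step involves a bromine on that ring, so the closest guide is that a methyl and a nitro on the same ring left the numbers unchanged beyond the scatter. On that basis compound 4 is expected to give a number near that of compound 2 in this assay, with a 1.1-fold higher number from compound 2 to compound 4 (0.05 log units; within the scatter) as the expected step. The estimate for compound 4 is 35000 nM, with a range from 15000 nM to 80000 nM.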

Compound 4, concentration for 50% growth inhibition: 6700 nM
Estimate against measurement, compound 4: 5.2-fold (0.72 log units) above; measured number below the stated range.
By their numbers in this assay, from the lowest: compound 4; then compounds 2, 1 and 3 (each within the scatter of the next).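

In this assay the ring on the aromatic nitrogen of the shared core gives its first step beyond the scatter: a bromine added to that ring gives a 4.7-fold lower number from compound 1 to compound 4 (0.67 log units; beyond the scatter), whereas the methyl and nitro groups left the number within the scatter. The 4-bromophenyl group also separates from both other substituted rings, with a 4.6-fold lower number from compound 2 to compound 4 (0.67 log units; beyond the scatter) and a 7.5-fold lower number from compound 3 to compound 4 (0.87 log units; beyond the scatter), so this position on the aromatic nitrogen is not indifferent to change. Nothing available gives a reason for these steps.

Open, going by these compounds, is whether the bromine itself or its place on the ring carries the steps, as the group and its place change together here. Also open, on these data alone, is how chlorine or an amine such as morpholine on that ring would read.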